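Swapping thiophene for thiazole on a fluorinated nucleoside

The source may report more compounds than this note shows. Statements on the series, on what has been measured and on what is new or still open speak of the compounds shown alone.

Values in a functional assay on HCT-116 cells (Homo sapiens), read by sulforhodamine B assay, with a stated time of 5 days; a higher number here means a weaker inhibitor of growth, a lower number a stronger inhibitor of growth:
- compound 1 `OC[C@H]1O[C@@H](n2cc(F)c3c(-c4ccccc4)ncnc32)[C@H](O)[C@@H]1O`: > 10000 nM
- compound 2 `OC[C@H]1O[C@@H](n2cc(F)c3c(-c4ccco4)ncnc32)[C@H](O)[C@@H]1O`: 39 nM
- compound 3 `OC[C@H]1O[C@@H](n2cc(F)c3c(-c4cccs4)ncnc32)[C@H](O)[C@@H]1O`: 9 nM

The value of compound 1, > 10000 nM, is a limit of the assay and not a number. Among the two true numbers, compound 3 stands lowest, making it the strongest inhibitor of growth of the three. The next compound, `OC[C@H]1O[C@@H](n2cc(F)c3c(-c4nccs4)ncnc32)[C@H](O)[C@@H]1O`, is compound 4, which carries 1,3-thiazol-2-yl in place of thiophen-2-yl on an aromatic carbon.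

Going by the values given here, three measured steps concern this same place. Two are large and start from phenyl: an at least 250-fold lower number from compound 1 to compound 2 (2.40 log units; beyond the scatter) and an at least 1100-fold lower number from compound 1 to compound 3 (3.04 log units; beyond the scatter). The closest guide is the exchange of one five-membered aromatic ring for another, a 4.3-fold lower number from compound 2 to compound 3 (0.64 log units; beyond the scatter), which was only modest. Compound 4 also keeps a five-membered aromatic ring, so a modest step is expected in this assay rather than a large one, most likely towards a higher number. The expected step is a 4.4-fold higher number from compound 3 to compound 4 (0.65 log units; beyond the scatter). For compound 4 the estimated value is 40 nM, with an expected range of 9 nM to 400 nM.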

Compound 4, concentration for 50% growth inhibition: 1300 nM
The estimate for compound 4 lay 33-fold (1.51 log units) below the measured number, outside the stated range (above it).
By their numbers in this assay, from the lowest: compound 3; then compound 2; then compound 4. At a limit, above all of these: compound 1.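

In this assay, going by these compounds alone, the earlier compounds could suggest that any five-membered aromatic ring at this position gives a low number, but compound 4 shows otherwise. With the ring size unchanged, the exchange of a ring carbon for nitrogen gives a 140-fold higher number from compound 3 to compound 4 (2.16 log units; beyond the scatter), and the comparison with furan-2-yl gives a 33-fold higher number from compound 2 to compound 4 (1.52 log units; beyond the scatter), so the position responds strongly to which hetero atoms the ring carries, while 1,3-thiazol-2-yl still gives an at least 7.6-fold lower number from compound 1 to compound 4 (0.88 log units; beyond the scatter). That last step has only one bound, since the value of compound 1 is a limit and not a number: the limit of > 10000 nM in this assay, at which 1 of the 4 values shown sits.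

Going by these compounds, it remains open whether a pyridin-2-yl ring, or a methyl group or an amine on the thiophen-2-yl ring, would keep the low number of compound 3. A 1,3-thiazol-5-yl group would show whether the loss follows the ring nitrogen itself or where it sits.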